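The source may hold more compounds than are shown below. What is called first, only, known or untested is meant among the compounds shown, and "the series" means these compounds.

Compound 1 `CC(C(=O)N1CCN(c2ccc(Cl)cc2)CC1)N1C(=O)CCC1=O`: 100%
Compound 2 `CCC(C(=O)N1CCN(c2cccc(F)c2)CC1)N1C(=O)CCC1=O`: 75%
Compound 3 `CCC(C(=O)N1CCN(c2cccc(Cl)c2)CC1)N1C(=O)CCC1=O`: 75%

In a functional assay on the whole organism (strain Swiss) with Mus musculus as the target, in the maximal electroshock model, with a stated time of 0.25 h, at a dose of 300 mg/kg by the intraperitoneal route (on this read-out lower numbers stand for a weaker effect and higher numbers for a stronger effect at the one dose given), compound 3 stands level with compound 2 and together with it gives the lowest of the three numbers, while compound 1 gives a number beyond the scatter above both. Among the compounds with values here, the one step within this set, no change at the digits printed from compound 2 to compound 3 (within the scatter), shows that a halogen exchange on the aromatic ring leaves the read-out unchanged. The unmeasured compound 4 `CCC(C(=O)N1CCN(c2ccc(Cl)cc2)CC1)N1C(=O)CCC1=O` differs from compound 3 by 4-chlorophenyl in place of 3-chlorophenyl on an amine nitrogen in a ring. Within the data shown here, no measured pair tests this change by itself: compound 1 carries the 4-chlorophenyl group but also a shorter chain, so its higher number cannot be credited to the ring position alone. Among the measured compounds shown here, what the data show is that compound 1, the only compound with 4-chlorophenyl, gives 100%, while compound 3 gives 75%. A modest upward step, a number 10 percentage points higher from compound 3 to compound 4 (within the scatter), is therefore expected, with wide uncertainty. Compound 4 is estimated to give 85%, ranging from 60% to 100%.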

Compound 4, a percentage reported as activity, at one dose (the size of the read-out at that dose, not a potency): 0%
For compound 4 the middle estimate is 85 percentage points above the measured one, and the stated range ends above it.
By their numbers in this assay, from the lowest: compound 4; then compounds 2 and 3 (each within the scatter of the next); then compound 1.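

In this assay, this position on the phenyl ring proves highly sensitive: with the same atoms joined differently, 4-chlorophenyl in place of 3-chlorophenyl gives a number 75 percentage points lower from compound 3 to compound 4 (beyond the scatter), and 4-chlorophenyl in place of 3-fluorophenyl gives a number 75 percentage points lower from compound 2 to compound 4 (beyond the scatter). The 4-chlorophenyl group does not settle the outcome by itself, since methyl in place of hydrogen on the saturated chain carbon gives a number 100 percentage points lower from compound 1 to compound 4 (beyond the scatter), so the result for this ring group depends on the chain that accompanies it. Nothing available here accounts for either change.

The compounds shown leave open how 4-fluorophenyl or 4-methoxyphenyl would behave on the ring nitrogen, and what a longer chain would do alongside 4-chlorophenyl. They also leave open whether the pattern holds at other doses and times.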